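A few compounds are considered here, and "the series" means these few. Any claim that something is new, unique, unknown or untested is made for them only; others in the source may bear on it.

Compound 1, `CC(=O)OCCc1c(C)[nH]c(=O)[nH]c1=O`. In a functional assay on SW-620 cells (Homo sapiens) for antiproliferative activity, read by MTT assay, with a stated time of 24 h (a lower number here means a stronger inhibitor, a higher number a weaker inhibitor), compound 1 gives only a limit, > 100000 nM. Compound 2, `CC(=O)OCCc1c(C)nc(Cl)nc1Cl`. Compound 2 also gives only a limit in this assay, > 100000 nM. Compound 3, `COc1ccc(C(OCCc2c(C)nc(OC)nc2OC)(c2ccccc2)c2ccccc2)cc1`. Compound 3 gives 20000 nM in this assay.

Compound 2 therefore stands at the limit of this assay, the same place described by the limit of > 100000 nM in this assay, at which 2 of the 3 values shown sit. Compound 4, `COc1nc(Cl)nc(C)c1CCOC(C)=O`, differs from compound 2 in one place: methoxy in place of chloro on an aromatic carbon. Among the compounds with values here, no measured pair shows this step, so its size is unknown. The step from compound 2 to compound 4 is expected to be a number no higher from compound 2 to compound 4 (the limit leaves the size open), within the scatter or at most a modest gain. Compound 4 is therefore estimated at 100000 nM, with a range from 30000 nM to 300000 nM, and a limit is the likelier outcome.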

Compound 4, half-maximal inhibitory concentration: > 100000 nM
Compound 4: only a limit was reported (the forecaster's own chance of this, stated with the estimate: 70%); the middle value lies on the limit itself.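

Compound 2 and compound 4 each give only a limit in this assay, and no step can be read between them. The compounds shown leave open whether methoxy in place of chloro on an aromatic carbon changes activity at all.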